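Chain Terminus Variation in a Catechol Vinyl Sulfone Series

This account rests on a few compounds, and the source may have more. Where it says the series, first, only, none or still open, it means among the compounds named here.

Three catechol vinyl sulfones with different saturated chains were measured in a functional assay, read by fluorescence and spectrophotometry, with a stated time of 1 h; a lower number here means that less compound is needed, a higher number that more compound is needed for the effect. Compound 1 `CCCCCCCCCCS(=O)(=O)/C=C/c1ccc(O)c(O)c1` gives 6800 nM. Compound 2 `CCCCCCCCCCCCS(=O)(=O)/C=C/c1ccc(O)c(O)c1` gives 8500 nM. Compound 3 `O=S(=O)(/C=C/c1ccc(O)c(O)c1)CCCCCCCO` gives 5900 nM, the lowest of the three numbers, but all three lie within the scatter of one another, so no order among them can be claimed. The steps that lead to compound 3 are small: a 1.2-fold lower number from compound 1 to compound 3 (0.06 log units; within the scatter), and a 1.4-fold lower number from compound 2 to compound 3 (0.16 log units; within the scatter); the step of a 1.3-fold higher number from compound 1 to compound 2 (0.10 log units; within the scatter) is likewise within the scatter.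

Compound 4 `CCCCCCCCCS(=O)(=O)/C=C/c1ccc(O)c(O)c1` has not yet been measured in this assay. It differs from compound 3 by ethyl in place of hydroxy on a saturated chain carbon, seven bonds along the chain from a sulfonyl sulfur. This change runs opposite to the steps from compound 1 and from compound 2 to compound 3, both of which stayed within the scatter, so no step beyond the scatter is expected in this assay, with at most a slightly higher number. The estimated step for compound 4 is a 1.1-fold higher number from compound 3 to compound 4 (0.04 log units; within the scatter). Compound 4 is therefore expected to give 6500 nM, within a range of 3500 nM to 12000 nM.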

Compound 4, half-maximal effective concentration: 7700 nM
The estimate for compound 4 lay 1.2-fold (0.07 log units) below the measured number; low and high end bracket the measured number.
By their numbers in this assay, from the lowest: compounds 3, 1, 4 and 2 (each within the scatter of the next).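

Ethyl in place of hydroxy on a saturated chain carbon, seven bonds along the chain from a sulfonyl sulfur, gives a 1.3-fold higher number from compound 3 to compound 4 (0.12 log units; within the scatter) in this assay and so adds a direct exchange of these two groups at this position to the earlier steps. The hydroxy leaves with its hydrogen-bond donor and acceptor, yet the number does not move beyond the scatter. Hydrogen in place of propyl, nine bonds along the chain, gives a 1.1-fold lower number from compound 2 to compound 4 (0.04 log units; within the scatter) and hydrogen in place of methyl at that same place gives a 1.1-fold higher number from compound 1 to compound 4 (0.05 log units; within the scatter) and neither separates the chains.

From the compounds shown here alone, whether an amine or a carboxylic acid at this position would give a step beyond the scatter remains open, as does the effect of a chain longer than that of compound 2. The data offer no explanation for how little these changes register.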